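This account rests on a few compounds, and the source may have more. Where it says the series, first, only, none or still open, it means among the compounds named here.

Working notes on a set of amides built on a shared core.

Compound 1 `O=C(Nc1nnc(-c2cccc(O)c2O)s1)C1CCCCC1` gives 19900 nM in a functional assay, with a stated time of 30 min, in the absence of a further agent; a higher number here means a weaker inhibitor, a lower number a stronger inhibitor. Compound 2 `O=C(COc1ccccc1)Nc1nnc(-c2cccc(O)c2O)s1` gives 16600 nM in this assay. Compound 3 `O=C(Nc1nnc(-c2ccc(O)c(O)c2)s1)c1ccccc1`, which differs from the other two at the carbonyl and in the core as well, gives 23400 nM in this assay. On these numbers compound 2 holds the lowest value of the three, but both neighbours sit within the scatter of it, so no ranking is claimed. Within the data shown here, the one single-point step recorded so far is a 1.2-fold lower number from compound 1 to compound 2 (0.08 log units; within the scatter), which is within the scatter.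

Compound 4 `O=C(Nc1nnc(-c2cccc(O)c2O)s1)c1ccc(Cl)cc1` is not yet measured. Relative to compound 2 the change is 4-chlorophenyl in place of phenoxymethyl on a carbonyl carbon. Among the measured compounds shown here, the only measured step that touches the same position is the one from compound 1 to compound 2, and it was within the scatter. Compound 3 carries an unsubstituted phenyl on its carbonyl, but it also differs in the core, so its value can only be noted, not read as a step. With a change of this kind at this position and no step beyond the scatter on record, the expected step in this assay is a 1.0-fold higher number from compound 2 to compound 4 (0.01 log units; within the scatter), that is, none beyond the scatter. For compound 4 the estimate in this assay is 17000 nM, with a range from 6000 nM to 50000 nM.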

Compound 4, half-maximal inhibitory concentration: 30200 nM
Compound 4: middle estimate off by 1.8-fold (0.25 log units), on the low side; the measured number falls inside the stated range.
By their numbers in this assay, from the lowest: compounds 2, 1, 3 and 4 (each within the scatter of the next).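

Within the shared core of compounds 1, 2 and 4, three different groups now stand on the carbonyl carbon in this assay and, with the new steps of a 1.8-fold higher number from compound 2 to compound 4 (0.26 log units; within the scatter) and a 1.5-fold higher number from compound 1 to compound 4 (0.18 log units; within the scatter) as well as the earlier step of a 1.2-fold lower number from compound 1 to compound 2 (0.08 log units; within the scatter) all within the scatter, no group can be ranked against another. The earlier compounds shown here offered only cyclohexyl and phenoxymethyl at this place; 4-chlorophenyl adds a chlorine-bearing aromatic ring and removes the oxygen of phenoxymethyl, yet the value of compound 4 stays within the scatter of both neighbours, so neither change registers as a measurable step here. No supporting data are available that would account for this flat picture.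

Still open, as far as these compounds go, is whether a group of another kind on the carbonyl carbon, such as an amine, a carboxylic acid or a longer chain, would give a step beyond the scatter in this assay on this core. From the compounds shown here alone, compound 3 differs from the other compounds in more than one place, so the separate contribution of its core remains open as well.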